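Moving Two Fluoro Groups on the Benzyl Phenyl Ring

A few compounds are considered here, and "the series" means these few. Any claim that something is new, unique, unknown or untested is made for them only; others in the source may bear on it.

Measured in a functional assay on MCF7 cells (Homo sapiens) for inhibition, read by MTT assay, with a stated time of 48 h; on this read-out lower numbers stand for stronger inhibition and higher numbers for weaker inhibition
Compound 1 `Fc1ccccc1CSc1nnc(-c2ccncc2)n1-c1ccccc1` gives > 50000 nM
Compound 2 `Clc1cccc(CSc2nnc(-c3ccncc3)n2-c2ccccc2)c1` gives 10500 nM
Compound 3 `Fc1ccc(CSc2nnc(-c3ccncc3)n2-c2ccccc2)c(F)c1` gives 14100 nM

The entry for compound 1 is a limit of the assay and not a number. The other two numbers in this assay lie close together, with a 1.3-fold higher number from compound 2 to compound 3 (0.13 log units; within the scatter) separating them, so neither can be ranked over the other. Both stand apart from the limit, as shown by an at least 4.7-fold lower number from compound 1 to compound 2 (0.67 log units; beyond the scatter) and by an at least 3.5-fold lower number from compound 1 to compound 3 (0.54 log units; beyond the scatter) in the same read-out.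

Compound 4 `Fc1cccc(F)c1CSc1nnc(-c2ccncc2)n1-c1ccccc1` has not yet been measured. The change that leads to it (2,6-difluorophenyl in place of 2,4-difluorophenyl on a saturated chain carbon bound to a sulfur) is 2,6-difluorophenyl in place of 2,4-difluorophenyl on a saturated chain carbon bound to a sulfur.

Among the measured compounds shown here, two measured steps bear on this change. The exchange of groups at the same place in a 1.3-fold higher number from compound 2 to compound 3 (0.13 log units; within the scatter) left the number within the scatter, which argues against a large move. By contrast, an at least 3.5-fold lower number from compound 1 to compound 3 (0.54 log units; beyond the scatter) shows that the fluoro pattern on this phenyl can matter, which leaves some room for weaker inhibition. A small move to a higher number is therefore expected, and it may not clear the scatter. The expected step is a 1.4-fold higher number from compound 3 to compound 4 (0.15 log units; within the scatter) in this assay and remains an estimate. The estimated value for compound 4 is 20000 nM, with an expected range from 9000 nM to 45000 nM.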

Compound 4, half-maximal inhibitory concentration: > 50000 nM
Compound 4: a limit, no number; the forecaster's own chance of this, stated with the estimate: 20%; middle value at least 2.5-fold (0.39 log units) from the limit.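

In this assay, changing 2,4-difluorophenyl to 2,6-difluorophenyl on a saturated chain carbon bound to a sulfur gives an at least 3.5-fold higher number from compound 3 to compound 4 (0.54 log units; beyond the scatter), so the arrangement of the two fluoro groups counts at this position even though the atoms stay the same, whereas the earlier exchange between compound 2 and compound 3 stayed within the scatter. The 3-chlorophenyl group of compound 2 also stands apart from the new group, with an at least 4.7-fold higher number from compound 2 to compound 4 (0.67 log units; beyond the scatter), while the step between compound 1 and compound 4 cannot be read. The entry for compound 4 is a limit of the assay and not a number, and compound 1 carries the same limit: the limit of > 50000 nM in this assay, at which 2 of the 4 values shown sit.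

Going by these compounds, how far compound 1 and compound 4 lie past that limit stays open, so the two cannot be ranked against each other. The compounds shown also leave open whether a methoxy group or an amine on this phenyl, or a longer chain in place of the benzyl link, would give a number in this assay.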